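The source may report more compounds than this note shows. Statements on the series, on what has been measured and on what is new or still open speak of the compounds shown alone.

Of the compounds shown here, three have been measured in a functional assay on MCF7 cells (Homo sapiens) for inhibition, read by MTT assay, with a stated time of 72 h; a lower number here means a stronger inhibitor of growth, a higher number a weaker inhibitor of growth. Compound 1 `O=S(=O)(NCCNCc1cccc2ccccc12)c1cc(C(F)(F)F)cc(C(F)(F)F)c1` gives 18000 nM, compound 2 `O=S(=O)(NCCNCc1ccc(-c2ccccc2)cc1)c1cc(C(F)(F)F)cc(C(F)(F)F)c1` gives 1400 nM, and compound 3 `O=S(=O)(NCCCNCc1ccc(C(F)(F)F)cc1)c1cc(C(F)(F)F)cc(C(F)(F)F)c1` gives 1400 nM. Compound 3 stands level with compound 2 at the digits shown, the two together the lowest numbers in this assay; compound 1 gives a higher number, beyond the scatter. The next compound, compound 4 `O=S(=O)(NCCCNCc1ccc(Cl)cc1)c1cc(C(F)(F)F)cc(C(F)(F)F)c1`, differs from compound 3 in one place: chloro in place of trifluoromethyl on an aromatic carbon. Within the data shown here, no measured pair carries this change, so its size is not known from the series. The step of a 1.3-fold higher number from compound 3 to compound 4 (0.11 log units; within the scatter) is expected to lie within the scatter. The estimate for compound 4 in this assay is 1800 nM, with a range from 700 nM to 4500 nM.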

Compound 4, concentration for 50% growth inhibition: 2400 nM
Compound 4: middle estimate off by 1.3-fold (0.12 log units), on the low side; the measured number falls inside the stated range.
By their numbers in this assay, from the lowest: compounds 2, 3 and 4 (each within the scatter of the next); then compound 1.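

In this assay, among these compounds, the first pair of the series differing in one place gives a 1.7-fold higher number from compound 3 to compound 4 (0.23 log units; within the scatter). At this aromatic carbon, para to a large group, chloro with one heavy atom thus stands in for trifluoromethyl with four, without a step beyond the scatter. No measurement here gives a reason for the step. Still open, from the compounds shown here alone, is how a methoxy group, an amine or a carboxylic acid would read on that carbon. Also open, going by these compounds, is whether the same change gives a similar step on a longer chain.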